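Replacing Cyclopropylcarbonyl with Ethyl on the Shared Core

This account rests on a few compounds, and the source may have more. Where it says the series, first, only, none or still open, it means among the compounds named here.

- Compound 1 `Cn1cc(-c2cnc3ccnc(N)c3c2)cn1` gives 40800 nM as a measured value
- Compound 2 `Cn1cc(-c2cnc3ccnc(NC(=O)C4CC4)c3c2)cn1` gives > 50000 nM as a limit

Both readings come from a functional assay on HeLa cells (Homo sapiens) for antiproliferative activity, read by MTT assay, with a stated time of 48 h (a higher number here means a weaker inhibitor, a lower number a stronger inhibitor), and compound 2 stands there only at a limit, with no number of its own. Within the data shown here, the one measured step that bears on the next change is an at least 1.2-fold higher number from compound 1 to compound 2 (0.08 log units; that floor lies within the scatter) and, being a floor within the scatter, it sets no size. Compound 3 `CCNc1nccc2ncc(-c3cnn(C)c3)cc12` differs from compound 2 by ethyl in place of cyclopropylcarbonyl on a nitrogen on an aromatic ring with ethyl in place of cyclopropylcarbonyl on a nitrogen on an aromatic ring. Compound 1 at 40800 nM also lacks cyclopropylcarbonyl on that nitrogen, so a value near it is expected for compound 3. In this assay the expected change is an at least 1.4-fold lower number from compound 2 to compound 3 (0.15 log units; that floor lies within the scatter) which would be small and toward a lower number. Compound 3 is estimated at 35000 nM within 12000 nM to 60000 nM as the expected range.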

Compound 3, half-maximal inhibitory concentration: > 50000 nM
Compound 3 ended at the assay's limit; the forecaster's own chance of this, stated with the estimate: 40%; at least 1.4-fold (0.15 log units) between middle value and limit.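

In this assay compound 3 gives > 50000 nM, which is a limit of the assay and not a number. Ethyl in place of hydrogen on this nitrogen gives an at least 1.2-fold higher number from compound 1 to compound 3 (0.08 log units; that floor lies within the scatter), so a group without a carbonyl here, like cyclopropylcarbonyl, also leaves no measured value, and neither substituted compound has a number of its own. The step between compound 2 and compound 3 cannot be read, so ethyl and cyclopropylcarbonyl cannot be ranked on this nitrogen, because the readings meet at the same limit: the limit of > 50000 nM in this assay, at which 2 of the 3 values shown sit.

Going by these compounds, whether a longer chain, a benzyl group or a carboxylic acid on this nitrogen would give a value inside the range of the assay stays open. With only compound 1 carrying a measured number, no order among the groups at this position can be drawn.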